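A few compounds are considered here, and "the series" means these few. Any claim that something is new, unique, unknown or untested is made for them only; others in the source may bear on it.

Measured compounds:
Compound 1, `CCCCC/C=C\C/C=C\CCCCCCCC1(O)CC(=O)c2c(O)cc(OCOC)cc2O1`, gives 16100 nM in a functional assay on MDA-MB-231 cells (Homo sapiens) for antiproliferative activity, read by MTT assay; a lower number here means a stronger inhibitor, a higher number a weaker inhibitor.
Compound 2, `CCCCC/C=C\C/C=C\CCCCCCCc1cc(=O)c2c(O)c(C)c(O)cc2o1`, gives 16100 nM in this assay.
Compound 3, `CCCCCCCCCCCCCCCc1cc(=O)c2c(O)c(C)c(O)cc2o1`, gives 42800 nM in this assay.

Compound 1 and compound 2 sit level at the digits printed, and the difference between their two cores is not broken down here. Within the core of compound 2, the change octyl in place of deca-1,4-dien-1-yl on a saturated chain carbon, seven bonds along the chain from an aromatic carbon brought a 2.7-fold higher number from compound 2 to compound 3 (0.42 log units; beyond the scatter). Compound 4, `CCCCCCCCCCCCCCCC1(O)CC(=O)c2c(O)cc(OCOC)cc2O1`, carries the same kind of change on the core of compound 1, (octyl in place of deca-1,4-dien-1-yl on a saturated chain carbon, seven bonds along the chain from a saturated ring carbon), the place differing only in that the chain runs seven bonds from a saturated ring carbon rather than from an aromatic carbon. For compound 4 the expected step is a 2.7-fold higher number from compound 1 to compound 4 (0.43 log units; beyond the scatter) because the same kind of change gave a 2.7-fold higher number from compound 2 to compound 3 (0.42 log units; beyond the scatter). Compound 4 is therefore estimated at 43000 nM, between 20000 nM and 95000 nM.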

Compound 4, half-maximal inhibitory concentration: > 87000 nM
Compound 4: a limit, no number (the forecaster's own chance of this, stated with the estimate: 15%); at least 2.0-fold (0.30 log units) between middle value and limit.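

Compound 4 gives > 87000 nM in this assay, and this value is a limit of the assay, not a number. On the core of the first pair, octyl in place of deca-1,4-dien-1-yl brought an at least 5.4-fold higher number from compound 1 to compound 4 (0.73 log units; beyond the scatter), which runs in the same direction as a 2.7-fold higher number from compound 2 to compound 3 (0.42 log units; beyond the scatter) on the other core. The direction of the change therefore carries from one core to the other, but its size is not settled: the same change on two cores in this assay, a 2.7-fold higher number (0.42 log units; beyond the scatter) from compound 2 to compound 3 and an at least 5.4-fold higher number (0.73 log units; beyond the scatter) from compound 1 to compound 4; the limit leaves it open whether they differ.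

The compounds shown leave open whether a shorter chain, a longer chain or a chain with a single double bond would follow the same direction on either core. Going by these compounds, how a chain carrying an amine or a carboxylic acid would fare on these two cores also stays open.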